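The source may hold more compounds than are shown below. What is called first, only, known or untested is meant among the compounds shown, and "the series" means these compounds.

Three compounds sharing one core have been measured in a functional assay on Malme-3M cells (Homo sapiens) for inhibition, read by sulforhodamine B assay, with a stated time of 48 h; a higher number here means a weaker inhibitor of growth, a lower number a stronger inhibitor of growth:

Compound 1 `COc1cc(-c2nn(-c3cccc(NC(=O)Nc4cc(C(F)(F)F)cc(C(F)(F)F)c4)c3)cc2-c2ccncc2)ccc1Cl` gives 2170 nM.
Compound 2 `COc1cc(-c2nn(-c3cccc(NC(=O)c4cccc(C(F)(F)F)c4)c3)cc2-c2ccncc2)ccc1Cl` gives only a limit, > 50000 nM.
Compound 3 `COc1cc(-c2nn(-c3cccc(NC(=O)Nc4ccc(Cl)c(Cl)c4)c3)cc2-c2ccncc2)ccc1Cl` gives 2420 nM.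

Compound 3 stands highest of the two numbers, with compound 1 within the scatter of it. Compound 4 `COc1cc(-c2nn(-c3cccc(NC(=O)Nc4cccc(C(F)(F)F)c4)c3)cc2-c2ccncc2)ccc1Cl` is not yet measured; it differs from compound 3 by 3-(trifluoromethyl)phenyl in place of 3,4-dichlorophenyl on an amide-type nitrogen. Going by the values given here, the one measured step, an at least 20-fold lower number from compound 2 to compound 3 (1.31 log units; beyond the scatter), concerns a different change, at the carbonyl carbon, and bears only loosely on this one. Compound 2 sits at the limit (the limit of > 50000 nM in this assay, at which 1 of the 3 values shown sits). Compound 1 and compound 3 show that two different groups at this position give similar numbers. The expected step is therefore a 1.2-fold higher number from compound 3 to compound 4 (0.09 log units; within the scatter), within the scatter. Compound 4 is estimated at 3000 nM, ranging from 1200 nM to 9000 nM.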

Compound 4, concentration for total growth inhibition: 2410 nM
Compound 4: middle estimate off by 1.2-fold (0.10 log units), on the high side; low and high end bracket the measured number.
By their numbers in this assay, from the lowest: compounds 1, 4 and 3 (each within the scatter of the next). At a limit, above all of these: compound 2.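

In this assay, the group on the amide-type nitrogen now changes alone without moving the number beyond the scatter: a 1.0-fold lower number from compound 3 to compound 4 (0.00 log units; within the scatter), and a 1.1-fold higher number from compound 1 to compound 4 (0.05 log units; within the scatter). With 3-(trifluoromethyl)phenyl held constant, the amino group on the carbonyl carbon is the only difference in an at least 20-fold lower number from compound 2 to compound 4 (1.31 log units; beyond the scatter). Compound 2 gives a limit, not a number: the limit of > 50000 nM in this assay, at which 1 of the 4 values shown sits.

On these data alone, it remains open whether the numbers stay level with a plain phenyl, a methoxy-substituted phenyl or a longer alkyl chain on the amide-type nitrogen.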